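The source may report more compounds than this note shows. Statements on the series, on what has been measured and on what is new or still open speak of the compounds shown alone.

Of the compounds shown here, two of a shared core have been tested in a functional assay on SK-MEL-2 cells (Homo sapiens) for inhibition, read by sulforhodamine B assay, with a stated time of 48 h, tested at 10 uM; on this read-out higher numbers stand for more inhibition at the one concentration tested (going by the name of the read-out) and lower numbers for less inhibition. Compound 1, `COc1ccccc1-c1cn2ccnc2c(-c2ccc3ncn(C4CCCCC4)c3c2)n1`, gives 12.1% in this assay. Compound 2, `c1cn2cc(-c3ccc4c(c3)ncn4C3CCCCC3)nc(-c3ccc4ncn(C5CCCCC5)c4c3)c2n1`, gives 13.7% in this assay; this is the higher of the two numbers, but the gap to compound 1 lies within the scatter, so the two cannot be told apart on this read-out.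

Compound 3, `c1ccc(Cn2cnc3ccc(-c4nc(-c5ccc6c(c5)ncn6C5CCCCC5)cn5ccnc45)cc32)cc1`, has not yet been measured in this assay. It differs from compound 2 in one place: benzyl in place of cyclohexyl on an aromatic nitrogen. Going by the values given here, no pair of measured compounds here differs in a single place, so there is no measured step from which the size of this change can be read off. The expectation is therefore a step of no more than the scatter in either direction, with the number for compound 3 staying near that of compound 2. The expected step of a number 1.3 percentage points higher from compound 2 to compound 3 (within the scatter) is small. In this assay compound 3 is estimated at 15%, within a range from 0% to 35%.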

Compound 3, a percentage reported as inhibition, at one concentration (the size of the read-out at that concentration, not a potency): -36.7%
The estimate for compound 3 lay 51.7 percentage points above the measured number; the whole stated range lies above it.
By their numbers in this assay, from the lowest: compound 3; then compounds 1 and 2 (each within the scatter of the next).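

In this assay, going by these compounds alone, the exchange on this aromatic nitrogen is far from neutral: benzyl in place of cyclohexyl gives a number 50.4 percentage points lower from compound 2 to compound 3 (beyond the scatter), so the read-out responds strongly to the group at this position, which no earlier single-place step could show. Compound 3 gives -36.7%, a negative number on a read-out of inhibition, so this change takes the value below zero rather than only towards it. No measurement shown here bears on why the step is so large.

The compounds shown leave open whether the step follows the aromatic ring of benzyl or the carbon that joins that ring to the nitrogen. A cyclohexylmethyl or a phenyl group on the same nitrogen would separate these two readings.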